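This account rests on a few compounds, and the source may have more. Where it says the series, first, only, none or still open, it means among the compounds named here.

Working notes on the series. Compound 1 `COc1ccc(/C=C\C(=O)O)c(OCc2cn(-c3ccc(NC(C)=O)cc3)nn2)c1CC=C(C)C`, compound 2 `COc1cccc(-n2cc(COc3c(/C=C\C(=O)O)ccc(OC)c3CC=C(C)C)nn2)c1`, compound 3 `COc1ccc(-n2cc(COc3c(/C=C\C(=O)O)ccc(OC)c3CC=C(C)C)nn2)cc1` and the not yet measured compound 4 `COc1ccc(/C=C\C(=O)O)c(OCc2cn(-c3cccnc3Cl)nn2)c1CC=C(C)C` share one core and differ only in the aryl group carried on an aromatic nitrogen. In a functional assay on A-431 cells (Homo sapiens) for cytotoxicity, read by MTT assay, with a stated time of 24 h (a higher number here means a weaker inhibitor, a lower number a stronger inhibitor), compound 1 gives 23400 nM. In this assay compound 2 gives 23200 nM. Among the compounds with values here, these are the only two numbers recorded, and compound 2 and compound 1 lie within the scatter of each other, so no order between them can be stated. For compound 3 the entry in this assay reads "not determined" (no result reported), so no number exists for it. The measured step of a 1.0-fold lower number from compound 1 to compound 2 (0.00 log units; within the scatter) replaces one aryl group on that nitrogen by another and produces nothing beyond the scatter.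

Compound 4 introduces (2-chloropyridin-3-yl in place of 3-methoxyphenyl on an aromatic nitrogen). Within the data shown here, the single step that bears on this exchange is a 1.0-fold lower number from compound 1 to compound 2 (0.00 log units; within the scatter), and it was flat. Accordingly, the change is expected to give a step of a 1.0-fold lower number from compound 2 to compound 4 (0.00 log units; within the scatter), that is, none beyond the scatter. Compound 4 is therefore estimated at 23000 nM in this assay, within a range of 10000 nM to 50000 nM.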

Compound 4, half-maximal inhibitory concentration: 32600 nM
Compound 4: the middle estimate sits 1.4-fold (0.15 log units) below what was measured, within the range that was stated.
By their numbers in this assay, from the lowest: compounds 2, 1 and 4 (each within the scatter of the next).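

The exchange in this assay gives a 1.4-fold higher number from compound 2 to compound 4 (0.15 log units; within the scatter) and, measured against the 4-acetamidophenyl compound, a 1.4-fold higher number from compound 1 to compound 4 (0.14 log units; within the scatter) as well. The position therefore now carries three different aryl groups with no step beyond the scatter, and this includes the first ring with a hetero atom, 2-chloropyridin-3-yl, which also brings in chlorine. No measured evidence bears on why these numbers stay together.

Steps involving compound 3 cannot be read, so the effect of moving methoxy around the phenyl ring remains unknown. Also open, from the compounds shown here alone, is whether any group on that aromatic nitrogen can move the number beyond the scatter, for example an aminophenyl group, a benzoic acid or a plain alkyl chain in place of the aryl ring.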